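The source may report more compounds than this note shows. Statements on the series, on what has been measured and on what is new or still open speak of the compounds shown alone.

Working notes on the series in a physicochemical assay for solubility; on this read-out lower numbers stand for lower solubility and higher numbers for higher solubility.

Compound 1 `O=C(c1cccc(Cl)c1)N1CCC(NS(=O)(=O)c2cc(S(=O)(=O)c3ccccc3)ccc2C(F)(F)F)CC1` gives 6300 nM in this assay. Compound 2 `O=C(c1ccccn1)N1CCC(NS(=O)(=O)c2cc(S(=O)(=O)c3ccccc3)ccc2C(F)(F)F)CC1` gives 100000 nM. Among the measured compounds shown here, the one step measured so far, a 16-fold higher number from compound 1 to compound 2 (1.20 log units; beyond the scatter), is the replacement of 3-chlorophenyl by pyridin-2-yl on the carbonyl carbon. Compound 2 thus stands with the highest of the two numbers, and its nearest neighbour is compound 1, which holds the lower number, separated from it by the step just given.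

Compound 3 `CC(C)(C)OC(=O)N1CCC[C@H]1C(=O)N1CCC(NS(=O)(=O)c2cc(S(=O)(=O)c3ccccc3)ccc2C(F)(F)F)CC1` has not been measured. It differs from compound 2 at the same carbonyl carbon: 1-(tert-butoxycarbonyl)pyrrolidin-2-yl in place of pyridin-2-yl on a carbonyl carbon. For the measured compounds named here, the only step that bears on this place is the large one from compound 1 to compound 2, which shows that this assay answers strongly to what sits on that carbonyl carbon. A substantial step is therefore expected here too, and since compound 2 already holds the highest number, the expected direction is downward, a 5.0-fold lower number from compound 2 to compound 3 (0.70 log units; beyond the scatter). For compound 3 the estimate in this assay is 20000 nM, with a range from 4000 nM to 100000 nM.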

Compound 3, solubility: 25000 nM
The estimate for compound 3 lay 1.3-fold (0.10 log units) below the measured number; low and high end bracket the measured number.
By their numbers in this assay, from the lowest: compound 1; then compound 3; then compound 2.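

On the carbonyl carbon, 1-(tert-butoxycarbonyl)pyrrolidin-2-yl gives a 4.0-fold lower number from compound 2 to compound 3 (0.60 log units; beyond the scatter) and a 4.0-fold higher number from compound 1 to compound 3 (0.60 log units; beyond the scatter) in this assay for this position. An aromatic ring at this place is therefore not required for a number above that of compound 1, and the non-aromatic group with its defined stereocentre places compound 3 between the two aromatic examples. The three groups now give three separate levels, each step beyond the scatter, but no measurement here accounts for any of these steps.

Open, as far as these compounds go, is whether the step belongs to the tert-butoxycarbonyl group or to the pyrrolidine ring, which a free pyrrolidin-2-yl amine on the same carbonyl carbon would separate. Also open, from the compounds shown here alone, is how the opposite stereocentre would read in this assay on this carbonyl carbon.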